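From compound 1 to its 2,4-dichlorophenyl analogue

The source may report more compounds than this note shows. Statements on the series, on what has been measured and on what is new or still open speak of the compounds shown alone.

Among the compounds with values here, compound 1 `Cc1cc(C)nc(Sc2ccc(NC(=O)Nc3ccccc3)cc2)n1` is the parent of the two compounds measured so far. In a functional assay on MCF7 cells (Homo sapiens) for cytotoxicity, read by MTT assay, with a stated time of 3 days (on this read-out higher numbers stand for weaker inhibition and lower numbers for stronger inhibition), compound 1 gives > 50000 nM, which is a limit of the assay rather than a number. Compound 2 `Cc1cc(C)nc(Sc2ccc(NC(=O)Nc3ccc(OC(F)(F)F)cc3)cc2)n1` differs from compound 1 by a trifluoromethoxy in place of hydrogen on an aromatic carbon; in this assay compound 2 gives 41700 nM. Within the data shown here, the only measured step, an at least 1.1-fold lower number from compound 1 to compound 2 (0.07 log units; that floor lies within the scatter), starts from the limit of > 50000 nM in this assay, at which 1 of the 2 values shown sits, and therefore shows little. Compound 3 `Cc1cc(C)nc(Sc2ccc(NC(=O)Nc3ccc(Cl)cc3Cl)cc2)n1` has not yet been measured. It differs from compound 1 by 2,4-dichlorophenyl in place of phenyl on an amide-type nitrogen. Among the measured compounds shown here, no measured step touches this change, and the one step that does exist stays within the scatter, so no movement beyond the scatter is expected for compound 3 in this assay. Compound 3 is estimated at 30000 nM, between 8000 nM and 100000 nM, and the step of an at least 1.6-fold lower number from compound 1 to compound 3 (0.22 log units; that floor lies within the scatter) is expected to remain small.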

Compound 3, half-maximal inhibitory concentration: > 50000 nM
Compound 3 gave a limit, no number; the forecaster's own chance of this, stated with the estimate: 40%; at least 1.6-fold (0.22 log units) between middle value and limit.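

In this assay compound 3 gives > 50000 nM, which is a limit and not a number. Within the data shown here, no step from compound 1 to compound 3 can be read, as both stand at a limit: the limit of > 50000 nM in this assay, at which 2 of the 3 values shown sit. The compounds shown leave open whether 2,4-dichlorophenyl in place of phenyl on an amide-type nitrogen changes the read-out in this assay at all.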